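Moving the chlorine around the benzyl ring of a weak inhibitor

This account rests on a few compounds, and the source may have more. Where it says the series, first, only, none or still open, it means among the compounds named here.

This account follows two measured compounds and one not yet measured. Compound 1 `CC(C)(C)c1cc(/C=C/C(=O)NCCC2CCN(Cc3ccc(F)cc3)CC2)cc(C(C)(C)C)c1O` and compound 2 `CC(C)(C)c1cc(/C=C/C(=O)NCCC2CCN(Cc3ccccc3Cl)CC2)cc(C(C)(C)C)c1O` share a core and differ only in the phenyl group on a saturated chain carbon bound to an amine nitrogen in a ring. In an assay on isolated protein for inhibition of Amine oxidase [flavin-containing] B (Homo sapiens), read by fluorescence, with stated times of 15 min and 20 min (a lower number here means a stronger inhibitor, a higher number a weaker inhibitor), compound 1 gives 11100 nM, and in this assay compound 2 gives 9800 nM. Within the data shown here, the step of a 1.1-fold lower number from compound 1 to compound 2 (0.05 log units; within the scatter) is the only measured step, and it lies within the scatter, so compound 2 and compound 1 cannot be told apart on these numbers. Compound 3 `CC(C)(C)c1cc(/C=C/C(=O)NCCC2CCN(Cc3cccc(Cl)c3)CC2)cc(C(C)(C)C)c1O` carries the change (3-chlorophenyl in place of 2-chlorophenyl on a saturated chain carbon bound to an amine nitrogen in a ring). Among the measured compounds shown here, no measured step moves the chlorine from one position of this phenyl ring to another, and the single step in hand, from one halophenyl to another, shows no movement beyond the scatter. Compound 3 is therefore expected to stay close to compound 2, with a step of about a 1.0-fold higher number from compound 2 to compound 3 (0.01 log units; within the scatter) in this assay. The estimate for compound 3 is 10000 nM, within a range of 4000 nM to 25000 nM.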

Compound 3, half-maximal inhibitory concentration: 8700 nM
For compound 3 the middle estimate is 1.1-fold (0.06 log units) above the measured one; the range from low to high includes it.
By their numbers in this assay, from the lowest: compounds 3, 2 and 1 (each within the scatter of the next).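

The first direct test of where the chlorine sits on this phenyl ring gives a 1.1-fold lower number from compound 2 to compound 3 (0.05 log units; within the scatter), so in this assay 2-chlorophenyl and 3-chlorophenyl cannot be told apart. The wider comparison gives a 1.3-fold lower number from compound 1 to compound 3 (0.11 log units; within the scatter), so 3-chlorophenyl cannot be told apart from 4-fluorophenyl either, and this position has so far shown no readable response to the halogen's identity or to the chlorine's placement. No supporting evidence bears on this result.

The compounds shown leave open whether the same holds for groups other than halogens on the phenyl ring, such as a methoxy group, a nitrile or a carboxylic acid. They also leave open what a longer chain would do in place of the saturated chain carbon bound to an amine nitrogen in a ring.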